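A few compounds are considered here, and "the series" means these few. Any claim that something is new, unique, unknown or untested is made for them only; others in the source may bear on it.

Compound 1 `Cc1ccccc1Nc1nc(Nc2ccc(N3CCN(C)CC3)cn2)ncc1Cl`: 7470 nM
Compound 2 `Cc1ccccc1Nc1nc(Nc2ccc(N3CCNCC3)cn2)ncc1Cl`: 5060 nM

In a functional assay on MDA-MB-231 cells (Homo sapiens) for inhibition, read by CCK-8 assay, with a stated time of 48 h (on this read-out lower numbers stand for stronger inhibition of growth and higher numbers for weaker inhibition of growth), compound 1 gives 7470 nM and compound 2 gives 5060 nM. With only these two numbers, lying within the scatter of each other, compound 1 holds no separate place on this read-out.

Compound 3 `COc1ccc(CNc2nc(Nc3ccc(N4CCN(C)CC4)cn3)ncc2Cl)cc1` keeps the core of compound 1 but differs at one place: 4-methoxybenzyl in place of 2-methylphenyl on a nitrogen on an aromatic ring. In words, 4-methoxybenzyl stands in place of 2-methylphenyl on a nitrogen on an aromatic ring.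

Going by the values given here, the only measured step, a 1.5-fold lower number from compound 1 to compound 2 (0.17 log units; within the scatter), is hydrogen in place of methyl on an amine nitrogen in a ring. Among the compounds with values here, that is a different place from the one changed in compound 3, so it bears on this change only indirectly. Within the data shown here, no measured compound varies the group on the nitrogen in question, so the data give neither a size nor a direction for it. No step beyond the scatter can be forecast in this assay, though the uncertainty is wide.

The expected step is a 1.1-fold lower number from compound 1 to compound 3 (0.03 log units; within the scatter). Compound 3 is estimated at 7000 nM, with an expected range from 2500 nM to 20000 nM.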

Compound 3, concentration for 50% growth inhibition: 14900 nM
Compound 3: middle estimate off by 2.1-fold (0.33 log units), on the low side; low and high end bracket the measured number.
By their numbers in this assay, from the lowest: compounds 2, 1 and 3 (each within the scatter of the next, the first and the last beyond it).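

Going by these compounds alone, compound 3 gives the first reading at this position: putting 4-methoxybenzyl in place of 2-methylphenyl on a nitrogen on an aromatic ring comes to a 2.0-fold higher number from compound 1 to compound 3 (0.30 log units; within the scatter) in this assay. The two groups are therefore not separated on this read-out, even though the entering group has more heavy atoms, an oxygen and a hydrogen-bond acceptor that the leaving group lacks. As this single pair lies within the scatter, it gives no firm direction for the change, and no measurement at hand bears on the result or offers an explanation for it.

Going by these compounds, what remains open is whether any group on this nitrogen can move the number beyond the scatter, and a plain benzyl, a 4-hydroxybenzyl or a cyclohexyl group would each give a further reading at the same place. Also open, on these data alone, is whether 4-methoxybenzyl would behave the same way in combination with the hydrogen on the ring amine nitrogen, the change that gave a 1.5-fold lower number from compound 1 to compound 2 (0.17 log units; within the scatter).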